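The compounds below may be only part of what the source reports. "The series", "measured", "known", "first", "only" and "open" are said of these compounds alone.

Measured compounds:
- compound 1 `COc1cc(N)c(Cl)cc1C(=O)NC1CCN(CCCCCCCCO)CC1` — 15.9 nM
- compound 2 `COc1cc(N)c(Cl)cc1C(=O)NC1CCN(CCCCCCCCS(=O)(=O)O)CC1` — 1000 nM
- compound 3 `COc1cc(N)c(Cl)cc1C(=O)NC1CCN(CCN2CCCCC2)CC1` — 100 nM

These three share one core and differ only in the chain on the ring nitrogen. In a functional assay on HEK293 cells for agonist activity at 5-hydroxytryptamine receptor 4 (Homo sapiens), read by cAMP accumulation (a higher number here means that more compound is needed for the effect, a lower number that less compound is needed), compound 2 gives the highest number of the three. The step to compound 4 `COc1cc(N)c(Cl)cc1C(=O)NC1CCN(CCCCCN2CCN(S(C)(=O)=O)CC2)CC1` is 4-(methylsulfonyl)piperazin-1-yl in place of 3-sulfopropyl on a saturated chain carbon, five bonds along the chain from an amine nitrogen in a ring: the acid on the chain goes, and a ring bearing a methylsulfonyl group arrives. Going by the values given here, two measured steps bear on this. The step of a 63-fold higher number from compound 1 to compound 2 (1.80 log units; beyond the scatter) shows that the sulfo group costs a great deal, and the step of a 10-fold lower number from compound 2 to compound 3 (1.00 log units; beyond the scatter) shows that exchanging it for a basic ring recovers part of that. A similar drop is therefore expected, with a 20-fold lower number from compound 2 to compound 4 (1.30 log units; beyond the scatter). Compound 4 is estimated at 50 nM, within 10 nM to 300 nM.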

Compound 4, half-maximal effective concentration: 12.6 nM
Beside the measured number, compound 4's estimate is 4.0-fold (0.60 log units) above it, and the stated range covers the measured number.
By their numbers in this assay, from the lowest: compounds 4 and 1 (each within the scatter of the next); then compound 3; then compound 2.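

In this assay the exchange of 3-sulfopropyl for 4-(methylsulfonyl)piperazin-1-yl gives a 79-fold lower number from compound 2 to compound 4 (1.90 log units; beyond the scatter) and so removes the whole cost seen for the sulfo group. Against the hydroxy end group there is a 1.3-fold lower number from compound 1 to compound 4 (0.10 log units; within the scatter) and so no real difference, which means this place on the chain accepts a large end group with a six-membered ring. A sulfur-bearing end group therefore need not raise the number as compound 2 does.

As far as these compounds go, whether a carboxylic acid at the chain end would behave like the sulfo group, or 4-(methylsulfonyl)piperazin-1-yl would keep this value on a shorter chain, remains open. Nothing available here explains why these end groups differ.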